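From Phenyl to Thiophene: Expecting Little Change

The source may report more compounds than this note shows. Statements on the series, on what has been measured and on what is new or still open speak of the compounds shown alone.

Of the compounds shown here, two sharing one core have been tested in a functional assay on HepG2 cells (Homo sapiens) for antiproliferative activity, read by MTT assay, with a stated time of 24 h; a higher number here means a weaker inhibitor, a lower number a stronger inhibitor. Compound 1 `COc1ccc(C(=O)/C=C/c2ccc([N+](=O)[O-])cc2)c2c1C=CC(C)(C)O2` carries a nitro group on an aromatic carbon and in this assay gives 2610 nM. Compound 2 `COc1ccc(C(=O)/C=C/c2ccccc2)c2c1C=CC(C)(C)O2` has hydrogen in place of that nitro. In this assay, on these data alone, compound 2 reaches only the limit of the measurement, > 10000 nM, so its exact number is unknown. Among the measured compounds shown here, the step of an at least 3.8-fold higher number from compound 1 to compound 2 (0.58 log units; beyond the scatter) is the only measured change in this set, and its size is bounded by the limit of > 10000 nM in this assay, at which 1 of the 2 values shown sits. Compound 2 therefore stands at the far end of what the numbers show.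

Compound 3 `COc1ccc(C(=O)/C=C/c2cccs2)c2c1C=CC(C)(C)O2` differs from compound 2 by thiophen-2-yl in place of phenyl on a double-bonded chain carbon bound to a double-bonded chain carbon. For the measured compounds named here, no measured step touches this exchange: the one measured step concerns a nitro group, not the ring itself, and so gives no direction for the thiophene. With nothing pointing up or down, the expectation for compound 3 in this assay is no step beyond the scatter, a step that the limit leaves unreadable from compound 2 to compound 3, with a fair chance that it again sits at the limit. Compound 3 is estimated at 12000 nM, within 4000 nM to 40000 nM.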

Compound 3, half-maximal inhibitory concentration: > 10000 nM
Compound 3: only a limit was reported; the forecaster's own chance of this, stated with the estimate: 65%; the middle value does not contradict the limit.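

In this assay compound 3 gives > 10000 nM, which is a limit of the assay and not a number. This shows that putting thiophen-2-yl in place of phenyl on a double-bonded chain carbon bound to a double-bonded chain carbon does not bring the value down to a readable number, but the step between these two compounds cannot be read, as both of their values are limits. Replacing the 4-nitrophenyl group with thiophen-2-yl gives an at least 3.8-fold higher number from compound 1 to compound 3 (0.58 log units; beyond the scatter), so among the compounds shown only the one carrying the nitro group has a measured number, and the other two cannot be ranked against each other: the limit of > 10000 nM in this assay, at which 2 of the 3 values shown sit.

On these data alone, how far compound 2 and compound 3 lie past the limit stays open, and so does any real difference between the phenyl and thiophen-2-yl rings. Also open, as far as these compounds go, is whether a nitro group on the thiophene ring would restore a readable number, and whether an amine or a nitrile in place of the nitro group on the phenyl ring would do the same.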